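The compounds below may be only part of what the source reports. "The series", "measured", "known", "first", "only" and "open" are said of these compounds alone.

Compound 1 `Nc1sc(-c2ccc(Cl)cc2)c(-c2ccc(Cl)cc2)c1C(=O)NC1CCC(O)CC1`: 5670 nM
Compound 2 `Nc1sc(-c2ccc(Cl)cc2)c(-c2ccc(Cl)cc2)c1C(=O)NCc1ccccc1`: 31800 nM
Compound 3 `COc1ccc(CNC(=O)c2c(N)sc(-c3ccc(Cl)cc3)c2-c2ccc(Cl)cc2)cc1`: 29500 nM

All three compounds share one core and differ only in the group carried by an amide-type nitrogen. In a functional assay on PC-3 cells (Homo sapiens) for inhibition, read by sulforhodamine B assay, with a stated time of 72 h (a lower number here means a stronger inhibitor, a higher number a weaker inhibitor), compound 3 gives 29500 nM, the second highest of the three numbers; its value and that of compound 2, 31800 nM, are within the scatter of each other (a 1.1-fold lower number from compound 2 to compound 3 (0.03 log units; within the scatter)), whereas compound 1, at 5670 nM, stands clearly apart (a 5.2-fold higher number from compound 1 to compound 3 (0.72 log units; beyond the scatter)).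

Compound 4 `Nc1sc(-c2ccc(Cl)cc2)c(-c2ccc(Cl)cc2)c1C(=O)NC1CC1` has not yet been measured. It differs from compound 3 in one place: cyclopropyl in place of 4-methoxybenzyl on an amide-type nitrogen. Among the compounds with values here, two measured steps bear on this. Going from compound 1 to compound 2 gave a 5.6-fold higher number from compound 1 to compound 2 (0.75 log units; beyond the scatter), and going from compound 1 to compound 3 gave a 5.2-fold higher number from compound 1 to compound 3 (0.72 log units; beyond the scatter): in both cases exchanging the saturated 4-hydroxycyclohexyl ring for a benzyl-type group raised the number by a modest amount. Within the data shown here, compound 4 returns to a saturated ring, though a smaller one and without the hydroxyl, and no measured step separates those two aspects. A modest drop in the number, roughly reversing the step from compound 1 to compound 3, is therefore expected for compound 4: a 3.3-fold lower number from compound 3 to compound 4 (0.52 log units; beyond the scatter). For compound 4 the estimate in this assay is 9000 nM, within 3000 nM to 27000 nM.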

Compound 4, half-maximal inhibitory concentration: 3680 nM
The estimate for compound 4 lay 2.4-fold (0.39 log units) above the measured number; low and high end bracket the measured number.
By their numbers in this assay, from the lowest: compounds 4 and 1 (each within the scatter of the next); then compounds 3 and 2 (each within the scatter of the next).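

In this assay, cyclopropyl on the amide-type nitrogen gives an 8.0-fold lower number from compound 3 to compound 4 (0.90 log units; beyond the scatter) and an 8.6-fold lower number from compound 2 to compound 4 (0.94 log units; beyond the scatter), so a group with only three carbons does clearly better here than either benzyl-type group. Set against the much larger 4-hydroxycyclohexyl, the same group gives a 1.5-fold lower number from compound 1 to compound 4 (0.19 log units; within the scatter), which means the two saturated rings cannot be told apart in this assay and that, among these four compounds, the hydroxyl and the larger ring are not needed for the lower numbers; the four fall into two groups, saturated rings low and benzyl-type groups high, with no compound going against that split. Nothing beyond these cell numbers is available to say why the benzyl-type groups fare worse.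

The compounds shown leave open whether a ring is needed at all, which an open chain such as isopropyl or n-butyl would test, and whether the hydroxyl has any effect on a six-membered ring, which plain cyclohexyl would test. They also do not separate the aromatic ring from the carbon linking it to the nitrogen, a question that phenyl attached directly to the nitrogen would address.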